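The compounds below may be only part of what the source reports. "The series", "measured", "known", "first", "only" and "open" are said of these compounds alone.

Working notes on the series. The shared core of compound 1 `COc1ccc(-c2ccc3ncn(-c4cc(OC)c(OC)c(OC)c4)c3c2)cc1` carries a 4-methoxyphenyl; compound 2 `COc1cc(-n2cnc3ccc(-c4ccc(O)cc4)cc32)cc(OC)c1OC` carries a 4-hydroxyphenyl and compound 3 `COc1cc(-n2cnc3ccc(-c4cccc(O)c4)cc32)cc(OC)c1OC` a 3-hydroxyphenyl. In a functional assay on A549 cells (Homo sapiens) for antiproliferative activity, read by MTT assay, with a stated time of 72 h (on this read-out higher numbers stand for weaker inhibition and lower numbers for stronger inhibition), compound 1 gives only a limit, > 10000 nM, which is the limit of > 10000 nM in this assay, at which 1 of the 3 values shown sits. Compound 2 gives 5090 nM in this assay, and compound 3 gives 250 nM. The step of an at least 1.9-fold lower number from compound 1 to compound 2 (0.29 log units; that floor lies within the scatter) is small, whereas an at least 40-fold lower number from compound 1 to compound 3 (1.60 log units; beyond the scatter) and a 20-fold lower number from compound 2 to compound 3 (1.31 log units; beyond the scatter) are large. On the numbers shown compound 3 stands lowest; its nearest neighbour is compound 2, and the step of a 20-fold lower number from compound 2 to compound 3 (1.31 log units; beyond the scatter) lies beyond the scatter.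

Compound 4 `COc1cc(-n2cnc3ccc(-c4ccc(C(C)=O)cc4)cc32)cc(OC)c1OC` is not yet measured. Its difference from compound 3 is 4-acetylphenyl in place of 3-hydroxyphenyl on an aromatic carbon. Among the measured compounds shown here, the steps that bear on it are a 20-fold lower number from compound 2 to compound 3 (1.31 log units; beyond the scatter) and an at least 40-fold lower number from compound 1 to compound 3 (1.60 log units; beyond the scatter), both showing that the 3-hydroxyphenyl of compound 3 sits well apart from the 4-methoxyphenyl and 4-hydroxyphenyl of compounds 1 and 2. Compound 4 returns to a group bearing its substituent in the position of compounds 1 and 2, so for this assay a large upward step a 16-fold higher number from compound 3 to compound 4 (1.20 log units; beyond the scatter) is expected. For compound 4 the estimate in this assay is 4000 nM, within 800 nM to 20000 nM.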

Compound 4, half-maximal inhibitory concentration: 2510 nM
Beside the measured number, compound 4's estimate is 1.6-fold (0.20 log units) above it; measured number inside the range.
By their numbers in this assay, from the lowest: compound 3; then compound 4; then compound 2. At a limit, above all of these: compound 1.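

In this assay the 4-acetylphenyl group shows that a substituent other than hydroxy or methoxy can stand on this phenyl, yet the number stays well above that of the 3-hydroxyphenyl, with a 10-fold higher number from compound 3 to compound 4 (1.00 log units; beyond the scatter). Between 4-hydroxyphenyl and 4-acetylphenyl the substituent itself moves the number, though far less than the change of group that leads to compound 3, with a 2.0-fold lower number from compound 2 to compound 4 (0.31 log units; beyond the scatter). Acetyl in place of methoxy gives an at least 3.9-fold lower number from compound 1 to compound 4 (0.60 log units; beyond the scatter), a step whose starting point, compound 1, is a limit: the limit of > 10000 nM in this assay, at which 1 of the 4 values shown sits.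

Still open, as far as these compounds go, is whether the low number of compound 3 belongs to the hydroxy group or to its place on the ring, a question that a 3-methoxyphenyl or 3-acetylphenyl would separate. Also open, from the compounds shown here alone, is how an amine or a carboxylic acid on this phenyl would read.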